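Trifluoromethyl in Place of Chloro on an Orexin Antagonist Series

This account rests on a few compounds, and the source may have more. Where it says the series, first, only, none or still open, it means among the compounds named here.

Compound 1 `Cc1nc(C(=O)N2CCC3(CC3)C[C@H]2CNc2ccc(C(F)(F)F)cn2)c(-c2ccccc2)s1`: < 5 in a functional assay on HEK293 cells for antagonist activity at Orexin receptor type 2 (Homo sapiens), read by FLIPR and calcium flux (a lower number here means a less potent compound, a higher number a more potent compound, by a factor of ten per unit of this negative logarithm), a limit of the assay rather than a number.
Compound 2 `Cc1nc(C(=O)N2CCC3(CC3)C[C@H]2CNc2ccc(Cl)cn2)c(-c2ccccc2)s1`: < 5 in this assay, again a limit of the assay rather than a number.
Compound 3 `Cc1nc(C(=O)N2CC3(CC3)C[C@H]2CNc2ccc(Cl)cn2)c(-c2ccccc2)s1`: 7.1 in this assay.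

Compound 2 and compound 1 share one core and differ only by trifluoromethyl in place of chloro on an aromatic carbon. The size of that step, a step that the two limits leave unreadable from compound 2 to compound 1, cannot be read because of the limit of < 5 in this assay, at which 2 of the 3 values shown sit. Compound 3 has a different core; how its core differs from that of compound 2 is not broken down here. Compound 4 `Cc1nc(C(=O)N2CC3(CC3)C[C@H]2CNc2ccc(C(F)(F)F)cn2)c(-c2ccccc2)s1` is compound 3 carrying the same change, (trifluoromethyl in place of chloro on an aromatic carbon), at the same place. Among the measured compounds shown here, the one measured pair with this change gives no readable size, so the expectation rests on compound 3 and its value of 7.1, with the swap assumed to change little. The step is expected to be a number 0.10 log units lower from compound 3 to compound 4 (within the scatter). Compound 4 is estimated at 7, most likely between 6.2 and 7.8.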

Compound 4, negative logarithm of the antagonist equilibrium constant: 7.7
Compound 4: middle estimate off by 0.70 log units, on the low side; the range from low to high includes it.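

On the core of compound 3, trifluoromethyl in place of chloro gives a readable result in this assay: the change is a number 0.60 log units higher from compound 3 to compound 4 (beyond the scatter). On the core of compound 2 the same change has no readable size, and compound 1 and compound 2 both stand at a limit of the assay rather than at a number: the limit of < 5 in this assay, at which 2 of the 4 values shown sit. The new step therefore shows that this change raises potency on one core, but it does not show that the change has the same size, or even the same direction, on the other core, so this is a single readable case and not a rule for the series.

The compounds shown leave open how a nitrile, a methoxy group or a plain hydrogen at this place on the pyridine ring would read in this assay. They also leave open whether the step seen here would hold on any third core.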